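Oxazolidinone Side-Chain Change and Expected Cell Toxicity

The source may report more compounds than this note shows. Statements on the series, on what has been measured and on what is new or still open speak of the compounds shown alone.

Measured compounds:
Compound 1, `O=C1O[C@@H](CSc2cccs2)CN1c1ccc(-n2cc(-c3ccccn3)cn2)c(F)c1`: > 400 ug/mL
Compound 2, `CCNC(=O)NC[C@H]1CN(c2ccc(-n3cc(-c4ccccn4)cn3)c(F)c2)C(=O)O1`: 29 ug/mL

The two measured compounds share a core and differ in one side chain only. In an ADME assay on HEK293-A cells (Homo sapiens) for cytotoxicity, read by MTT assay, with a stated time of 48 h (a lower number here means a stronger inhibitor, a higher number a weaker inhibitor), compound 1 gives > 400 ug/mL, which is a limit of the assay rather than a number. In this assay, within the data shown here, compound 2 gives 29 ug/mL, the only plain number among the two values shown. Between them, an at least 13-fold lower number from compound 1 to compound 2 (1.13 log units; beyond the scatter).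

Compound 3 is `CONC(=O)[C@H]1CN(c2ccc(-n3cc(-c4ccccn4)cn3)c(F)c2)C(=O)O1`. Its change from compound 2: methoxycarbamoyl in place of ((ethylcarbamoyl)amino)methyl on a saturated ring carbon. Among the measured compounds shown here, no measured step concerns this change; the one known step exchanges a different group for the one that now leaves. The data therefore give no size or direction for this step, and a wide range is expected. Compound 3 is estimated at 60 ug/mL, expected to lie between 15 ug/mL and 400 ug/mL. This estimate implies an expected step of a 2.1-fold higher number from compound 2 to compound 3 (0.32 log units; beyond the scatter).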

Compound 3, half-maximal inhibitory concentration: > 400 ug/mL
Compound 3 gave a limit, no number; the forecaster's own chance of this, stated with the estimate: 30%; middle value at least 6.6-fold (0.82 log units) away from the limit.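

In this assay, putting methoxycarbamoyl in place of ((ethylcarbamoyl)amino)methyl on this saturated ring carbon gives an at least 13-fold higher number from compound 2 to compound 3 (1.13 log units; beyond the scatter). The value of compound 3 is a limit of the assay and not a number, so this step has only a minimum size. Compound 2 now stands alone with a plain number, while the step between compound 1 and compound 3 cannot be read, and two different side chains end at the same limit: the limit of > 400 ug/mL in this assay, at which 2 of the 3 values shown sit.

On these data alone, it remains open which part of ((ethylcarbamoyl)amino)methyl goes with the lower number of compound 2. An aminomethyl group, or a longer chain ending in the same ethylcarbamoyl unit, on the same ring carbon would test this in the same assay.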